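The source may report more compounds than this note shows. Statements on the series, on what has been measured and on what is new or still open speak of the compounds shown alone.

Compound 1, with the structure `COC(=O)C1C(C)N=CN1Nc1cccc(Cl)c1`, was tested in a functional assay on MT4 cells (Homo sapiens) for cytotoxicity (on this read-out lower numbers stand for higher toxicity in this test and higher numbers for lower toxicity in this test), where compound 1 gives 107000 nM. Compound 2, with the structure `COC(=O)C1C(C)N=C(S)N1Nc1cccc(Cl)c1`, differs from it by sulfanyl in place of hydrogen on a carbon with a double bond to nitrogen; in this assay compound 2 gives 190000 nM, so that a 1.8-fold higher number from compound 1 to compound 2 (0.25 log units; within the scatter).

Compound 3, with the structure `Cc1cccc(NN2C=NC(C)C2C)c1`, has a different core, and the difference between the two cores is not broken down here. In this assay compound 3 gives 312000 nM, which stands beyond the scatter from the number of compound 1 but within the scatter of the number of compound 2.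

Compound 4, with the structure `Cc1cccc(NN2C(S)=NC(C)C2C)c1`, has not yet been measured. It differs from compound 3 by sulfanyl in place of hydrogen on a carbon with a double bond to nitrogen. For the measured compounds named here, this is the same kind of change as the one from compound 1 to compound 2, but the surroundings differ: here the carbon sits two ring bonds from two ring atoms that each bear a methyl group, whereas in compound 1 one of those ring atoms bears a methoxycarbonyl group. Because a 1.8-fold higher number from compound 1 to compound 2 (0.25 log units; within the scatter) stayed within the scatter, the step from compound 3 to compound 4 in this assay is expected to be similarly small, about a 1.3-fold higher number from compound 3 to compound 4 (0.11 log units; within the scatter). On that basis compound 4 is estimated to give roughly 400000 nM in this assay, most likely falling in the range from 200000 nM to 800000 nM.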

Compound 4, half-maximal cytotoxic concentration: 360000 nM
Beside the measured number, compound 4's estimate is 1.1-fold (0.05 log units) above it; measured number inside the range.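

In this assay, sulfanyl in place of hydrogen on a carbon with a double bond to nitrogen gives a 1.2-fold higher number from compound 3 to compound 4 (0.06 log units; within the scatter). Set beside the earlier case, the two cores show no difference that these numbers can resolve: the same change on two cores in this assay, a 1.8-fold higher number (0.25 log units; within the scatter) from compound 1 to compound 2 and a 1.2-fold higher number (0.06 log units; within the scatter) from compound 3 to compound 4, 1.5-fold (0.19 log units) apart, within the scatter of two such steps. In these two pairs, then, the change carries over from one core to the other with both steps inside the usual scatter, but this does not prove that the change has no effect at all, and two pairs cannot show how it would behave on any further core.

The compounds shown leave open whether a different group on that same carbon, such as an amine or a carboxylic acid, would give a step beyond the scatter. They also leave open how sulfanyl would read out at any other place on these cores, and whether the agreement seen here would hold on any other read-out.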